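A few compounds are considered here, and "the series" means these few. Any claim that something is new, unique, unknown or untested is made for them only; others in the source may bear on it.

Within the data shown here, in a functional assay on MCF7 cells (Homo sapiens) for antiproliferative activity, read by MTT assay, with stated times of 24 h and 72 h (on this read-out higher numbers stand for weaker inhibition and lower numbers for stronger inhibition), compound 3 (`COc1cc(N2C(=O)[C@@H](Oc3ccccc3)[C@H]2c2cc(N)c(OC)c(O)c2)cc(OC)c1OC`) gives 8800 nM, the lowest number of the three measured so far. Compound 1 (`COc1cc(N2C(=O)[C@@H](Oc3ccccc3)[C@H]2c2ccc(N(C)C)cc2)cc(OC)c1OC`) gives 31000 nM and compound 2 (`COc1cc(N2C(=O)[C@@H](Oc3ccccc3)[C@H]2c2ccc(C#N)cc2)cc(OC)c1OC`) gives 31600 nM. Exchanging dimethylamino for cyano gave a 1.0-fold higher number from compound 1 to compound 2 (0.01 log units; within the scatter).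

Compound 4 (`COc1cc(N2C(=O)[C@@H](Oc3ccccc3)[C@H]2c2ccc(N)cc2)cc(OC)c1OC`) is still unmeasured. The change leading to it is a group of 7 heavy atoms (6 carbon, 1 nitrogen; one six-membered aromatic ring of carbon only) in place of a group of 10 heavy atoms (7 carbon, 1 nitrogen, 2 oxygen; one six-membered aromatic ring of carbon only), on a saturated ring carbon. 4-Aminophenyl enters on a saturated ring carbon of a four-membered non-aromatic ring with 1 nitrogen, and the group of 10 heavy atoms leaves.

Among the measured compounds shown here, two measured steps bear on this change, and both run towards compound 3, the opposite direction: a 3.5-fold lower number from compound 1 to compound 3 (0.55 log units; beyond the scatter) and a 3.6-fold lower number from compound 2 to compound 3 (0.56 log units; beyond the scatter). Both are modest. The entering group, like those of compound 1 and compound 2, lacks the oxygen atoms of the leaving group, so compound 4 is expected to lose most of the gain seen in a 3.6-fold lower number from compound 2 to compound 3 (0.56 log units; beyond the scatter). For the measured compounds named here, no measured compound carries 4-aminophenyl itself, so the range stays wide.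

In this assay, a modest move to a higher number is expected, estimated as a 3.0-fold higher number from compound 3 to compound 4 (0.47 log units; beyond the scatter). For compound 4 the estimated value is 26000 nM, with an expected range of 10000 nM to 60000 nM.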

Compound 4, half-maximal inhibitory concentration: 160000 nM
Beside the measured number, compound 4's estimate is 6.2-fold (0.79 log units) below it; the measured number lies above the stated range.
By their numbers in this assay, from the lowest: compound 3; then compounds 1 and 2 (each within the scatter of the next); then compound 4.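

In this assay, among these compounds, the aryl group on the saturated ring carbon of the four-membered ring can shift the number further than the earlier compounds showed: the change to 4-aminophenyl gives a large step (an 18-fold higher number from compound 3 to compound 4 (1.26 log units; beyond the scatter)), whereas the earlier steps at this place were modest. Dimethylamino and cyano had given numbers within the scatter of each other, so the aromatic substituent had seemed to matter little, yet amino stands clearly apart from both (a 5.2-fold higher number from compound 1 to compound 4 (0.71 log units; beyond the scatter); a 5.1-fold higher number from compound 2 to compound 4 (0.70 log units; beyond the scatter)), and the numbers of compound 1 and compound 2 therefore do not mark the high end for aryl groups without the oxygen atoms of the group in compound 3. No measurement is available that would account for these steps.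

The compounds shown do not separate the contributions of the hydroxy and methoxy groups of compound 3, as neither appears alone with the amino group on the aryl ring. Also open, from the compounds shown here alone, is where a methylamino group or a carboxylic acid would fall in place of amino on the same ring.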